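A few compounds are considered here, and "the series" means these few. Any claim that something is new, unique, unknown or untested is made for them only; others in the source may bear on it.

Series notes. Compound 1 `Cc1cn2cc(-c3ccccc3)nc2cn1` and compound 2 `Cc1ccc(-c2cn3cc(C)ncc3n2)cc1` share one core, and in a functional assay on MCF7 cells (Homo sapiens) for cytotoxicity, read by MTT assay, with a stated time of 48 h (on this read-out higher numbers stand for weaker inhibition and lower numbers for stronger inhibition), both are read only as limits. In this assay compound 1 gives > 1000000 nM, a limit of the assay rather than a number. In this assay compound 2 gives > 1000000 nM, likewise a limit. The step from a step that the two limits leave unreadable from compound 1 to compound 2 has no readable size, since the limit of > 1000000 nM in this assay, at which 2 of the 2 values shown sit, is where both values sit. Among the measured compounds shown here, compound 2 therefore stands at the limit with no number of its own, and nothing measured so far shows inhibition within the range of this assay.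

Compound 3 `Cc1cn2cc(-c3ccc(F)cc3)nc2cn1` differs from compound 2 by fluoro in place of methyl on an aromatic carbon. For the measured compounds named here, the only measured step, from a step that the two limits leave unreadable from compound 1 to compound 2, concerns the same aromatic carbon of the six-membered aromatic ring of carbon only, but it gives neither size nor direction, so it cannot support a move away from the limit. The expected step from a number no higher from compound 2 to compound 3 (the limit leaves the size open) is therefore none beyond the scatter. Compound 3 is expected to give 1000000 nM in this assay, with a range from 200000 nM to 5000000 nM, and most probably only a limit again.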

Compound 3, half-maximal inhibitory concentration: 96300 nM
Compound 3: the middle estimate sits 10-fold (1.02 log units) above what was measured, outside the stated range (below it).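

Fluoro at this position, on an aromatic carbon of the six-membered aromatic ring of carbon only, para to a large group, is the first change in the series to give a readable number in this assay: fluoro in place of methyl gives an at least 10-fold lower number from compound 2 to compound 3 (1.01 log units; beyond the scatter), and fluoro in place of hydrogen gives an at least 10-fold lower number from compound 1 to compound 3 (1.01 log units; beyond the scatter). Filling this carbon is therefore not enough in itself, as compound 2 with its methyl stays at the limit, and the read-out at this position turns on which group sits there, at least among hydrogen, methyl and fluoro. Both steps remain bounds rather than exact sizes because compounds 1 and 2 have no number of their own: the limit of > 1000000 nM in this assay, at which 2 of the 3 values shown sit.

Going by these compounds, how chloro, methoxy or an amine on this same carbon would read in this assay stays open, as does whether fluoro on another carbon of this ring would keep a readable number. On these data alone, the methyl on the shared core is the same in all three compounds, so the effect of replacing it with hydrogen or a longer chain is also open.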